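From Allyl to Butyl on a Shared Core

The source may report more compounds than this note shows. Statements on the series, on what has been measured and on what is new or still open speak of the compounds shown alone.

- compound 1 `CCCCCCCCCCNC(=O)C1C(C(=O)O)[C@@H]2CC[C@H]1O2`: 10000 nM
- compound 2 `Cc1cc(C)c(NC(=O)C2C(C(=O)O)[C@@H]3CC[C@H]2O3)c(C)c1`: 10000 nM
- compound 3 `C=CCNC(=O)C1C(C(=O)O)[C@@H]2CC[C@H]1O2`: 10000 nM

These three compounds were measured in an ADME assay on BE(2)-C cells (Homo sapiens) for cytotoxicity, read by MTT assay, with a stated time of 72 h; a higher number here means a weaker inhibitor of growth, a lower number a stronger inhibitor of growth. At the digits reported, compound 3 stands level with the other two, and its distance to each lies within the scatter. Within the data shown here, no pair among them differs in one place only, so no measured step is available as a direct guide.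

The next compound to be tested is compound 4 `CCCCNC(=O)C1C(C(=O)O)[C@@H]2CC[C@H]1O2`, which has not yet been measured. Its difference from compound 3 is propyl in place of vinyl on a saturated chain carbon bound to an amide-type nitrogen. Put in words, propyl takes the place of vinyl on a saturated chain carbon bound to an amide-type nitrogen, which can also be read as allyl to butyl. One double bond outside aromatic rings leaves with this change.

The groups on that nitrogen differ among the measured compounds, yet compound 1 gives 10000 nM and compound 2 gives 10000 nM in this assay, the same as compound 3. Nothing beyond the scatter is therefore expected, and no direction is favoured. The expected change is no change at the digits printed from compound 3 to compound 4 (within the scatter). For compound 4 the estimated value is 10000 nM, with an expected range of 5000 nM to 20000 nM.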

Compound 4, concentration for 50% growth inhibition: 10000 nM
For compound 4 middle estimate and measured number coincide at the digits printed, within the range that was stated.
By their numbers in this assay, from the lowest: compounds 1, 2, 3 and 4 (each within the scatter of the next).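

In this assay, among these compounds, the first direct readings at this position are now available, and neither shows a change beyond the scatter. Taking propyl in place of vinyl on a saturated chain carbon bound to an amide-type nitrogen, which removes the one double bond outside aromatic rings, gives no change at the digits printed from compound 3 to compound 4 (within the scatter) and so shows that, in this pair, neither that double bond nor the difference of one carbon registers in the number. Hydrogen in place of hexyl on a saturated chain carbon, four bonds along the chain from an amide-type nitrogen, gives no change at the digits printed from compound 1 to compound 4 (within the scatter) and extends the same reading to a much larger change in chain length, from decyl to butyl.

The compounds shown leave open whether a group of another kind at the end of the butyl chain, such as an amine or a hydroxyl group, would move the value in this assay. Why these two changes leave the number as it stood also stays open, as no further measurement bears on the result.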